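A Longer Phenoxy Chain on the Crown Ether Ester

This account rests on a few compounds, and the source may have more. Where it says the series, first, only, none or still open, it means among the compounds named here.

Measured compounds:
Compound 1, `O=C(CCCCCc1ccccc1)OCC1COCCOCCOCCOCCOCCO1`, in a functional assay on SW1573 cells (Homo sapiens) for inhibition, read by sulforhodamine B assay, with a stated time of 48 h (on this read-out higher numbers stand for weaker inhibition of growth and lower numbers for stronger inhibition of growth), gives 78000 nM.
Compound 2, `O=C(CCCCC1CCCCC1)OCC1COCCOCCOCCOCCOCCO1`, gives 51000 nM.
Compound 3, `O=C(CCCc1cc2ccccc2[nH]1)OCC1COCCOCCOCCOCCOCCO1`, reaches only the assay limit of > 100000 nM.

All three share the same crown ether ester core and differ only in the group at the far end of the chain. Compound 1 holds the highest of the two actual numbers, and its nearest neighbour is compound 2, with a 1.5-fold lower number from compound 1 to compound 2 (0.18 log units; within the scatter). Compound 3 gave no number, only the limit (the limit of > 100000 nM in this assay, at which 1 of the 3 values shown sits). The steps that end at this limit, an at least 1.2-fold higher number from compound 1 to compound 3 (0.10 log units; that floor lies within the scatter) and an at least 1.9-fold higher number from compound 2 to compound 3 (0.29 log units; that floor lies within the scatter), have floors that also lie within the scatter. So far, swapping the terminal group has moved nothing clearly.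

Compound 4, `O=C(CCCCCCCCCCOc1ccccc1)OCC1COCCOCCOCCOCCOCCO1`, has not been measured. Its change from compound 1 is 5-phenoxypentyl in place of phenyl on a saturated chain carbon, five bonds along the chain from a carbonyl carbon, which lengthens the chain and adds an ether oxygen before the ring. Since every measured change at this end of the chain stayed within the scatter, no step beyond the scatter is expected here either, in either direction.

Compound 4 is therefore estimated at 65000 nM, within a range of 20000 nM to 200000 nM. This corresponds to an expected change of a 1.2-fold lower number from compound 1 to compound 4 (0.08 log units; within the scatter).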

Compound 4, concentration for 50% growth inhibition: 24000 nM
For compound 4 the middle estimate is 2.7-fold (0.43 log units) above the measured one; the range from low to high includes it.
By their numbers in this assay, from the lowest: compound 4; then compounds 2 and 1 (each within the scatter of the next). At a limit, above all of these: compound 3.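

In this assay, putting 5-phenoxypentyl in place of phenyl on a saturated chain carbon, five bonds along the chain from a carbonyl carbon, gives a 3.3-fold lower number from compound 1 to compound 4 (0.51 log units; beyond the scatter), a modest step toward stronger inhibition of growth. This is the first step among the compounds shown that clearly moves the number, so the far end of the chain is not as indifferent to change as the earlier comparisons suggested. The data shown offer no explanation for this step.

The change also bundles two things together, a longer chain and an ether oxygen, and the compounds shown cannot separate them: a chain of the same length ending in phenyl with carbon in place of that oxygen would tell which one matters. Going by these compounds, it also remains open whether a still longer chain would push the number lower, or whether an amine or a carboxylic acid at the far end of the 5-phenoxypentyl chain would keep the step.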